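This account rests on a few compounds, and the source may have more. Where it says the series, first, only, none or still open, it means among the compounds named here.

Of the compounds shown here, three have been measured so far. Compound 1 `N=C(N)NCCC[C@H](N)C(=O)NS(=O)(=O)OC[C@H]1OC[C@@H](n2cnc3c(N)ncnc32)C[C@@H]1O` gives 600 nM in a functional assay on PBMC cells (Homo sapiens) for inhibition; a higher number here means a weaker inhibitor, a lower number a stronger inhibitor. Compound 3 `N=C(N)NCCC[C@H](N)C(=O)NS(=O)(=O)OC[C@H]1OC[C@@H](n2cnc3c(N)ncnc32)[C@H](O)[C@@H]1O` gives 600 nM in this assay. Compound 2 `CSCC[C@H](N)C(=O)NS(=O)(=O)OC[C@H]1OC[C@@H](n2cnc3c(N)ncnc32)[C@H](O)[C@@H]1O` gives 5200 nM in this assay.

Compound 1 is compound 3 with one change, (hydrogen in place of hydroxy on a saturated ring carbon), and that change made a step of no change at the digits printed from compound 3 to compound 1 (within the scatter). Compound 2 and compound 3 share all but one part: a group of 2 heavy atoms (1 carbon, 1 sulfur; no ring) in place of a group of 5 heavy atoms (2 carbon, 3 nitrogen; no ring), on a saturated chain carbon, three bonds along the chain from an amine nitrogen and a carbonyl carbon. Going the other way, the step was an 8.7-fold lower number from compound 2 to compound 3 (0.94 log units; beyond the scatter), so compound 2 stands highest of the three.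

Compound 4 `CSCC[C@H](N)C(=O)NS(=O)(=O)OC[C@H]1OC[C@@H](n2cnc3c(N)ncnc32)C[C@@H]1O` has not yet been measured. It is compound 2 with the same change that turns compound 3 into compound 1: hydrogen in place of hydroxy on a saturated ring carbon. The place of the change is described in the same words for both pairs, so this is the same change on a different core. Because that change gave no change at the digits printed from compound 3 to compound 1 (within the scatter), compound 4 is expected to sit close to compound 2, with an estimated step of a 1.0-fold lower number from compound 2 to compound 4 (0.02 log units; within the scatter). Within the data shown here, only one earlier example of the change exists, so the expectation rests on a single step. Compound 4 is therefore estimated at 5000 nM, within 2000 nM to 13000 nM.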

Compound 4, half-maximal inhibitory concentration: 5500 nM
Beside the measured number, compound 4's estimate is 1.1-fold (0.04 log units) below it; measured number inside the range.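

In this assay, hydrogen in place of hydroxy on the saturated ring carbon gave a 1.1-fold higher number from compound 2 to compound 4 (0.02 log units; within the scatter), so the step seen on the first core also held on the second: the same change on two cores in this assay, no change at the digits printed (within the scatter) from compound 3 to compound 1 and a 1.1-fold higher number (0.02 log units; within the scatter) from compound 2 to compound 4, 1.1-fold (0.02 log units) apart, within the scatter of two such steps

The exchange of the group of 5 heavy atoms for the group of 2 heavy atoms gave a 9.2-fold higher number from compound 1 to compound 4 (0.96 log units; beyond the scatter), and the gap between this exchange on the two cores was equally small: the same change on two cores in this assay, an 8.7-fold lower number (0.94 log units; beyond the scatter) from compound 2 to compound 3 and a 9.2-fold lower number (0.96 log units; beyond the scatter) from compound 4 to compound 1, 1.1-fold (0.02 log units) apart, within the scatter of two such steps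

Across these four compounds the two changes therefore add up without any sign of interaction, but this rests on one pair of steps for each change in a single assay and does not show that it holds for other side chains or other ring changes.

The compounds shown leave open whether fluorine in place of the same hydroxy, or hydrogen in place of the remaining hydroxy group, would carry across the two cores in the same way. They also leave open how a side chain ending in a primary amine or a carboxylic acid would behave on either core.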